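A few compounds are considered here, and "the series" means these few. Any claim that something is new, unique, unknown or untested is made for them only; others in the source may bear on it.

Measured so far in a functional assay on COLO 205 cells (Homo sapiens) for inhibition, read by MTT assay, with a stated time of 24 h; a higher number here means a weaker inhibitor, a lower number a stronger inhibitor:
Compound 1 `[O-]/[N+](=C\c1cn(-c2ccc(Cl)cc2)nn1)c1ccccc1` gives 9700 nM.
Compound 2 `[O-]/[N+](=C\c1cn(CCC(F)(F)C(F)(F)C(F)(F)C(F)(F)C(F)(F)C(F)(F)C(F)(F)C(F)(F)F)nn1)c1ccccc1` gives only a limit, > 100000 nM.
Compound 3 `CCCCCCCCCCn1cc(/C=[N+](\[O-])Cc2ccccc2)nn1` gives only a limit as well, > 100000 nM.

Compound 2 therefore stands not at a number but at the edge of what this assay reports, and it shares that position with compound 3: the limit of > 100000 nM in this assay, at which 2 of the 3 values shown sit. Compound 1 is the only one of the three with a measured value, and since no pair of these compounds differs in a single place, no measured step connects compound 2 to either of the others. Its own value is a limit, so nothing in the data says how far past that edge it lies.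

Compound 4 `CC(C)(C)/[N+]([O-])=C/c1cn(CCC(F)(F)C(F)(F)C(F)(F)C(F)(F)C(F)(F)C(F)(F)C(F)(F)C(F)(F)F)nn1` is the next in line. It differs from compound 2 in one place, (tert-butyl in place of phenyl on a double-bonded nitrogen), while the long fluorinated chain on the triazole is kept. Among the compounds with values here, no measured step of this kind exists here, and the starting point is a limit, so the step from compound 2 to compound 4 is expected to be a number no higher from compound 2 to compound 4 (the limit leaves the size open), that is, none beyond the scatter. Compound 4 is accordingly estimated at 100000 nM, within 30000 nM to 300000 nM, with the most likely outcome being another limit rather than a number.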

Compound 4, half-maximal inhibitory concentration: 28800 nM
Compound 4: the middle estimate sits 3.5-fold (0.54 log units) above what was measured; measured number below the stated range.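

With compound 4, the group on the double-bonded nitrogen proves able to move the result in this assay: with the long fluorinated chain on the triazole kept, tert-butyl in place of phenyl brings an at least 3.4-fold lower number from compound 2 to compound 4 (0.54 log units; beyond the scatter). Within the data shown here, this is the first measured step in the set, and it shows that the long fluorinated chain does not hold every compound that carries it at the edge of the assay, since compound 4 returns a number where compound 2 does not. On these data alone, the full size of the step remains unknown because compound 2 holds a limit and not a number: the limit of > 100000 nM in this assay, at which 2 of the 4 values shown sit.

The change swaps an aromatic ring for a branched group without a ring, so the compounds shown do not tell which of these two differences matters, and a cyclohexyl or isopropyl group on the same nitrogen would help to separate them. They also leave open whether tert-butyl would bring a similar step alongside the other groups on the triazole, such as the chlorine-bearing aromatic ring of compound 1 or the plain carbon chain of compound 3.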